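The source may report more compounds than this note shows. Statements on the series, on what has been measured and on what is new or still open speak of the compounds shown alone.

In an ADME assay on HepG2 cells (Homo sapiens) for cytotoxicity, read by MTT assay, with a stated time of 48 h (on this read-out higher numbers stand for weaker inhibition and lower numbers for stronger inhibition), three compounds built on one shared core have been read so far. Compound 1 (`O=S(=O)(c1ccc(-c2ccc3ncnc(Nc4ccc(O)c(Cl)c4)c3c2)cc1)N1CCOCC1`) gives > 15000 nM, which is a limit of the assay and not a number. Compound 2 (`COc1ccc(Nc2ncnc3ccc(-c4ccc(S(=O)(=O)N5CCOCC5)cc4)cc23)cc1Cl`) gives > 15000 nM, again a limit. Compound 3 (`O=S(=O)(c1ccc(-c2ccc3ncnc(Nc4ccc(OCc5cccc(Cl)c5)c(Cl)c4)c3c2)cc1)N1CCOCC1`) gives > 15000 nM, also a limit. Compound 3 therefore stands with the others: the limit of > 15000 nM in this assay, at which 3 of the 3 values shown sit.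

Compound 4 (`O=S(=O)(c1ccc(-c2ccc3ncnc(Nc4ccc(OCc5cccc(F)c5F)c(Cl)c4)c3c2)cc1)N1CCOCC1`) has 2,3-difluorophenyl in place of 3-chlorophenyl on a saturated chain carbon bound to an oxygen on an aromatic ring. Two measured changes at this oxygen bear on it, a step that the two limits leave unreadable from compound 1 to compound 3 and a step that the two limits leave unreadable from compound 2 to compound 3, and a third, a step that the two limits leave unreadable from compound 1 to compound 2, sits at the same place. None of them has a readable size, so they give no direction and no step beyond the scatter is expected in this assay. The expected step is a step that the limit leaves unreadable from compound 3 to compound 4. Compound 4 is estimated at 20000 nM, with an expected range from 10000 nM to 40000 nM, and most likely will again be reported only as a limit.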

Compound 4, half-maximal inhibitory concentration: > 15000 nM
Compound 4: a limit, no number (the forecaster's own chance of this, stated with the estimate: 85%); the middle value is on the limit's open side.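

In this assay, within the data shown here, compound 4 gives only a limit, as do compound 1, compound 2 and compound 3, so no step among them can be read: the limit of > 15000 nM in this assay, at which 4 of the 4 values shown sit. The compounds shown leave open whether any group on this oxygen changes the cytotoxicity, since none has yet given a readable value.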